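The source may hold more compounds than are shown below. What is called first, only, known or untested is meant among the compounds shown, and "the series" means these compounds.

Series notes. The shared core of compound 1 `CCC1(CCCCN2CCN(c3ccccc3OC)CC2)C(=O)Nc2ccccc21` carries, on an amine nitrogen in a ring, an aromatic group that is varied across the set. In an assay on membranes from frontal cortex for displacement of a labelled ligand from Adrenergic receptor alpha-1 (Rattus norvegicus), read by scintillation counting, with a stated time of 45 min (on this read-out higher numbers stand for weaker inhibition and lower numbers for stronger inhibition), compound 1 gives 27 nM. Compound 2 `CCC1(CCCCN2CCN(c3ccccc3Cl)CC2)C(=O)Nc2ccccc21` gives 64 nM, and compound 3 `CCC1(CCCCN2CCN(c3cccc(Cl)c3)CC2)C(=O)Nc2ccccc21` gives 31 nM. Among the three numbers compound 3 stands second highest; its nearest neighbour is compound 1, the two lying within the scatter, and its furthest is compound 2. The step of a 2.4-fold higher number from compound 1 to compound 2 (0.37 log units; beyond the scatter) is modest, as is the step of a 2.1-fold lower number from compound 2 to compound 3 (0.31 log units; beyond the scatter), whereas the step of a 1.1-fold higher number from compound 1 to compound 3 (0.06 log units; within the scatter) stays within the scatter.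

Compound 4 `CCC1(CCCCN2CCN(c3ccc(F)cc3)CC2)C(=O)Nc2ccccc21` differs from compound 3 in one place: 4-fluorophenyl in place of 3-chlorophenyl on an amine nitrogen in a ring. The swaps of the aromatic group seen so far bear on this change: a 1.1-fold higher number from compound 1 to compound 3 (0.06 log units; within the scatter) and a 2.1-fold lower number from compound 2 to compound 3 (0.31 log units; beyond the scatter) moved the number little, and a 2.4-fold higher number from compound 1 to compound 2 (0.37 log units; beyond the scatter) only modestly. The resulting step is therefore expected to be a 1.8-fold higher number from compound 3 to compound 4 (0.25 log units; within the scatter), modest at most and likelier toward a higher number. Compound 4 is estimated at 55 nM, within a range of 18 nM to 170 nM.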

Compound 4, inhibition constant: 39 nM
The estimate for compound 4 lay 1.4-fold (0.15 log units) above the measured number, and the stated range covers the measured number.
By their numbers in this assay, from the lowest: compounds 1, 3, 4 and 2 (each within the scatter of the next, the first and the last beyond it).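

In this assay, going by these compounds alone, the 4-fluorophenyl group, the first fluorine-bearing aromatic group in the set, stays within the scatter of all three earlier groups on the amine nitrogen in a ring (a 1.3-fold higher number from compound 3 to compound 4 (0.10 log units; within the scatter)) (a 1.6-fold lower number from compound 2 to compound 4 (0.22 log units; within the scatter)) (a 1.4-fold higher number from compound 1 to compound 4 (0.16 log units; within the scatter)). Compound 4 thus lies within the scatter of both compound 2 and compound 3, although that pair is separated beyond it (a 2.1-fold lower number from compound 2 to compound 3 (0.31 log units; beyond the scatter)), so this position accepts a change of halogen and of its place on the aromatic group with no step beyond the scatter. No measurement at hand accounts for this result.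

Still open, as far as these compounds go, is whether an unsubstituted phenyl or a pyridine ring on this nitrogen would stay within the same narrow band. A carboxylic acid or an amine on the aromatic group, or a longer chain on the shared core, also remains untested in what is shown here.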